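The source may report more compounds than this note shows. Statements on the series, on what has been measured and on what is new or still open speak of the compounds shown alone.

Among the measured compounds shown here, in a functional assay on SNB-19 cells (Homo sapiens) for antiproliferative activity, read by sulforhodamine B assay, with a stated time of 48 h (on this read-out lower numbers stand for stronger inhibition and higher numbers for weaker inhibition), compound 1 `O=C(NCCCNc1cc(-c2cn(-c3ccccc3)nc2-c2cccc(O)c2)ccn1)Nc1ccc(F)cc1` gives 3290 nM as one of only two measured numbers. For the measured compounds named here, its single neighbour, compound 2 `O=C(NCCCNc1cc(-c2cn(-c3ccccc3)nc2-c2cccc(O)c2)ccn1)Nc1cccc(C(F)(F)F)c1`, gives 3990 nM in the same test, and the two lie within the scatter of each other. Compound 3 `COc1cccc(-c2nn(-c3ccccc3)cc2-c2ccnc(NCCCNC(=O)Nc3ccc(F)cc3)c2)c1` keeps the core of compound 1 and changes one place (methyl in place of hydrogen on an oxygen on an aromatic ring), hydroxy to methoxy, with methyl in place of hydrogen on an oxygen on an aromatic ring. Going by the values given here, the only measured step of a 1.2-fold higher number from compound 1 to compound 2 (0.08 log units; within the scatter) lies elsewhere, on an amide-type nitrogen, and stayed within the scatter, so no measurement speaks directly to this oxygen. A small move toward a higher number is therefore expected, with no clear passage beyond the scatter. The expected step is a 1.5-fold higher number from compound 1 to compound 3 (0.18 log units; within the scatter) in this assay on this reasoning. For compound 3 the estimate is 5000 nM with an expected range from 2200 nM to 11500 nM in that test.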

Compound 3, half-maximal inhibitory concentration: 12100 nM
The estimate for compound 3 lay 2.4-fold (0.38 log units) below the measured number; the whole stated range lies below it.
By their numbers in this assay, from the lowest: compounds 1 and 2 (each within the scatter of the next); then compound 3.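

In this assay, replacing the 3-hydroxyphenyl of compound 1 with 3-methoxyphenyl gives a 3.7-fold higher number from compound 1 to compound 3 (0.57 log units; beyond the scatter), so weaker inhibition follows from adding a single methyl on this oxygen. This is the first change shown to pass beyond the scatter, whereas the change on the amide-type nitrogen, a 1.2-fold higher number from compound 1 to compound 2 (0.08 log units; within the scatter), did not, and the oxygen on the aromatic ring is therefore a place where this read-out responds to substitution. No available evidence bears on why the methyl has this effect.

From the compounds shown here alone, the result rests on one pair, with the 4-fluorophenyl group held constant, so it remains open whether the same step would appear with the 3-(trifluoromethyl)phenyl group of compound 2. Going by these compounds, it also remains open how an ethoxy group, an amine or a fluorine in place of the hydroxy would read in this assay.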